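The compounds below may be only part of what the source reports. "The series", "measured", "known", "first", "only" and "open" are said of these compounds alone.

Compound 1 `Cc1ccccc1S(=O)(=O)NC(=O)c1ccc(Nc2nc(NC3(c4ccc(Cl)cc4)CC3)nc(OCC(F)(F)F)n2)cc1` gives 265 nm/s in a physicochemical assay for permeability, using PAMPA, at pH 7.4; a lower number here means that the compound crosses the layer more slowly, a higher number that the compound crosses the layer faster.
Compound 2 `CC(C)(C)OC(=O)NCCS(=O)(=O)NC(=O)c1ccc(Nc2nc(NC3(c4ccc(Cl)cc4)CC3)nc(OCC(F)(F)F)n2)cc1` gives 111 nm/s in this assay.
Compound 3 `CCS(=O)(=O)NC(=O)c1ccc(Nc2nc(NC3(c4ccc(Cl)cc4)CC3)nc(OCC(F)(F)F)n2)cc1` gives 28 nm/s in this assay.

Of the three measured compounds, compound 3 gives the lowest number. The steps of a 9.5-fold lower number from compound 1 to compound 3 (0.98 log units; beyond the scatter) and a 4.0-fold lower number from compound 2 to compound 3 (0.60 log units; beyond the scatter) both lie beyond the scatter, so compound 3 sits clearly below both of its neighbours. The three compounds share one core and differ only in the group on the sulfonyl sulfur, and each trimming of that group has so far lowered the number, as the steps of a 2.4-fold lower number from compound 1 to compound 2 (0.38 log units; beyond the scatter) and a 4.0-fold lower number from compound 2 to compound 3 (0.60 log units; beyond the scatter) show.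

Compound 4 `CS(=O)(=O)NC(=O)c1ccc(Nc2nc(NC3(c4ccc(Cl)cc4)CC3)nc(OCC(F)(F)F)n2)cc1` continues in the same direction: hydrogen in place of methyl on a saturated chain carbon bound to a sulfonyl sulfur. Among the compounds with values here, the steps that bear on it are those from compound 1 and compound 2 to compound 3, both downward and both modest. The change here is the smallest of the series, a single carbon, so a further drop is expected but a small one, likely not far beyond the scatter. The expected step is a 1.6-fold lower number from compound 3 to compound 4 (0.19 log units; within the scatter). Compound 4 is therefore estimated at 18 nm/s in this assay, with a range from 7 nm/s to 45 nm/s.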

Compound 4, apparent permeability: 11 nm/s
The estimate for compound 4 lay 1.6-fold (0.21 log units) above the measured number; low and high end bracket the measured number.
By their numbers in this assay, from the lowest: compound 4; then compound 3; then compound 2; then compound 1.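

Removing a single carbon at this position, ethyl to methyl on the sulfonyl sulfur, still moves the number in this assay beyond the scatter (a 2.5-fold lower number from compound 3 to compound 4 (0.41 log units; beyond the scatter)), so even the smallest change in the series registers here and the downward run has not levelled off at the small end. Within the data shown here, the wider comparisons extend that range: the step that replaces the ((tert-butoxycarbonyl)amino)methyl group with hydrogen is a 10-fold lower number from compound 2 to compound 4 (1.00 log units; beyond the scatter), and the one that puts methyl in place of 2-methylphenyl is a 24-fold lower number from compound 1 to compound 4 (1.38 log units; beyond the scatter), the first step that counts as large rather than modest. Nothing at hand explains why the number falls along this series.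

The four compounds leave open whether the high number of compound 1 belongs to the aromatic ring itself or to the methyl on it, a question that an unsubstituted phenyl or a benzyl group on the sulfonyl sulfur would address. They also leave open how a longer chain such as butyl, or a chain ending in a free amine or a carboxylic acid, would read in this assay.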